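The source may report more compounds than this note shows. Statements on the series, on what has been measured and on what is new or still open speak of the compounds shown alone.

Notes on the series. Compound 1 `CCOC(=O)c1ccc(NCc2cncn2Cc2ccc(-c3ccccc3)cc2)cc1-c1ccccc1` and compound 2 `O=C(OC1CCCCC1)c1ccc(NCc2cncn2Cc2ccc(-c3ccccc3)cc2)cc1-c1ccccc1` share a core and differ only in the ester. In a toxicity assay on NIH3T3 cells (Mus musculus) for cytotoxicity, read by resazurin assay (on this read-out higher numbers stand for an effect only at larger amounts of compound and lower numbers for an effect already at smaller amounts), compound 1 gives > 10000 nM, which is a limit of the assay and not a number. In this assay compound 2 gives > 10000 nM, again a limit. The step that the two limits leave unreadable from compound 1 to compound 2 therefore cannot be read in size or direction; what stands out is only (the limit of > 10000 nM in this assay, at which 2 of the 3 values shown sit).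

Compound 3 `COC(=O)c1ccc(NCc2cncn2Cc2ccccc2F)cc1-c1ccccc1` carries a methyl ester and a 2-fluorobenzyl group. In this assay compound 3 gives "not determined" (no result reported), so no number is known for it. Among the compounds with values here, the only values shown are those of compound 1 and compound 2, both of them limits of the assay.

Compound 4 `COC(=O)c1ccc(NCc2cncn2Cc2ccc(C)cc2)cc1-c1ccccc1` differs from compound 3 as 4-methylphenyl in place of 2-fluorophenyl on a saturated chain carbon bound to an aromatic nitrogen. No measured step bears on this change, and the one step shown, from compound 1 to compound 2, is unreadable. The expectation is that compound 4, like compound 1 and compound 2, gives no effect up to the limit. Compound 4 is estimated at 15000 nM, with a range from 7000 nM to 40000 nM.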

Compound 4, half-maximal effective concentration: 50000 nM
Compound 4: middle estimate off by 3.3-fold (0.52 log units), on the low side, outside the stated range (above it).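

In this assay compound 4 gives 50000 nM, but no new step can be read from compound 3 to compound 4, since compound 3 carries no numerical value. The compounds shown leave open what 4-methylbenzyl in place of 2-fluorobenzyl does in this assay.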